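A few compounds are considered here, and "the series" means these few. Any claim that something is new, unique, unknown or untested is made for them only; others in the source may bear on it.

Measured so far in a functional assay on HeLa cells (Homo sapiens) for inhibition; a lower number here means a stronger inhibitor, a higher number a weaker inhibitor:

Compound 1 `O=C(CC(CC(=O)NC1Cc2ccccc2C1)c1ccccc1)NCCN1CCCCC1` gives > 100000 nM, a limit.
Compound 2 `CCN(CC)CCNC(=O)CC(CC(=O)NC1Cc2ccccc2C1)c1ccccc1` gives > 100000 nM, a limit.
Compound 3 `Cc1ccc(C(CC(=O)NCCN2CCCCC2)CC(=O)NC2Cc3ccccc3C2)cc1` gives > 100000 nM, a limit.

Compound 1 therefore stands without a true number, held only by its limit of > 100000 nM. The same holds for the two compounds measured alongside it, which all sit at the limit of > 100000 nM in this assay, at which 3 of the 3 values shown sit.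

Compound 4 `CCN(C(=O)CC(CC(=O)NCCN1CCCCC1)c1ccccc1)C1Cc2ccccc2C1` carries ethyl in place of hydrogen on an amide-type nitrogen, whose other neighbours are a carbonyl carbon and a saturated ring carbon: ethyl in place of hydrogen on an amide-type nitrogen.

Two measured steps stand nearest to this change. One is a step that the two limits leave unreadable from compound 1 to compound 2. The other is a step that the two limits leave unreadable from compound 1 to compound 3. Neither changes the amide-type nitrogen, and neither has a size that can be read, so they give no measure for the new step. What they do show is that compound 2 and compound 3 both stay at the limit, and no change tried so far has produced a number in this assay.

On that basis, no readable step and no direction can be expected in this assay, and compound 4 is expected to remain very weak, most likely at the limit again. The expected step is a step that the limit leaves unreadable from compound 1 to compound 4. For compound 4 the estimated value is 120000 nM, with an expected range from 40000 nM to 400000 nM.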

Compound 4, half-maximal inhibitory concentration: > 100000 nM
Compound 4: no number, only a limit; the forecaster's own chance of this, stated with the estimate: 85%; the middle value is on the limit's open side.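

In this assay compound 4 gives > 100000 nM, a limit and not a number. Compound 1 is also held only by a limit, so the step between compound 1 and compound 4 cannot be read. The compounds shown leave open whether any of them has a true value in this assay, and what size the ethyl change has.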